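The source may hold more compounds than are shown below. What is called first, only, known or untested is meant among the compounds shown, and "the series" means these compounds.

Measured in a functional assay on HEp-2 cells (Homo sapiens) for inhibition; a lower number here means that less compound is needed, a higher number that more compound is needed for the effect:
- compound 1 `CC(=O)O[C@H]1[C@H](C2CN(C)CCN(C)C2=O)[C@H](OC(=O)/C=C/c2ccccc2)C[C@@H](C)[C@@H]2C=CC(=O)[C@]21C`: 0.84 ug/mL
- compound 2 `C[C@@H]1C[C@@H](OC(=O)/C=C/c2ccccc2)[C@@H](C2CN(C)CCN(C)C2=O)[C@H](O)[C@]2(C)C(=O)C=C[C@@H]12`: 2.89 ug/mL

Compound 2, at 2.89 ug/mL, holds the higher of the two numbers in this assay. Compound 3 `C[C@@H]1C[C@@H](OC(=O)/C=C/c2ccccc2)[C@@H](C2CN(C)CCN(C)C2=O)[C@H](OC(=O)/C=C/c2ccccc2)[C@]2(C)C(=O)C=C[C@@H]12` departs from it by (2-phenylethenyl)carbonyl in place of hydrogen on an oxygen on a saturated carbon.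

Within the data shown here, one measured step bears on this change: a 3.4-fold higher number from compound 1 to compound 2 (0.54 log units; beyond the scatter), with hydrogen in place of acetyl on that same oxygen. Read in reverse, it links acylation of this oxygen with a lower number. However, no measured compound carries (2-phenylethenyl)carbonyl there, so the transfer is uncertain.

A modest move toward a lower number in this assay is expected, reasoning from compound 1 at 0.84 ug/mL. The expected change is a 2.4-fold lower number from compound 2 to compound 3 (0.38 log units; beyond the scatter). For compound 3 the estimate is 1.2 ug/mL. The expected range for compound 3 runs from 0.4 ug/mL to 4 ug/mL.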

Compound 3, concentration for half-maximal effect: 0.75 ug/mL
Compound 3: middle estimate off by 1.6-fold (0.20 log units), on the high side; the range from low to high includes it.
By their numbers in this assay, from the lowest: compounds 3 and 1 (each within the scatter of the next); then compound 2.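

In this assay, acylation of this oxygen is no longer tied to acetyl alone: (2-phenylethenyl)carbonyl in place of hydrogen gives a 3.9-fold lower number from compound 2 to compound 3 (0.59 log units; beyond the scatter) and so matches in direction the link seen with acetyl. The two esters are not separated here, as 2-phenylethenyl in place of methyl on the carbonyl carbon gives a 1.1-fold lower number from compound 1 to compound 3 (0.05 log units; within the scatter) and this much larger acyl group leaves the number unresolved from that of the acetyl ester. No measurement on these compounds bears on the reason for the link between acylation and the lower number.

Going by these compounds, whether the link depends on the ester itself stays open, since a methyl ether or a carbamate on this oxygen would test that. Also open, on these data alone, is whether an acyl group carrying an amine or a carboxylic acid would keep the number of the two esters.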